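The compounds below may be only part of what the source reports. "The series", "measured", "known", "first", "only" and "open" are said of these compounds alone.

In an ADME assay on THP-1 cells (Homo sapiens) for cytotoxicity, read by MTT assay, with a stated time of 72 h (on this read-out lower numbers stand for an effect already at smaller amounts and higher numbers for an effect only at larger amounts of compound), compound 1 `Cc1cc(-c2ccc3[nH]c(=O)nc(-c4ccccc4)c3c2)ccn1` gives only an assay limit, > 50000 nM. Compound 2 `Cn1nccc1-c1ccc2[nH]c(=O)nc(-c3ccccc3)c2c1` likewise gives only a limit, > 50000 nM. The step that the two limits leave unreadable from compound 1 to compound 2 thus cannot be read, because both values sit at the limit of > 50000 nM in this assay, at which 2 of the 2 values shown sit. Compound 3 `Cc1ccc2[nH]c(=O)nc(-c3ccccc3)c2c1` differs from compound 2 by methyl in place of 1-methyl-1H-pyrazol-5-yl on an aromatic carbon. For the measured compounds named here, the single measured step offers no readable size, so no shift beyond the scatter is expected, and the change is estimated as a number no higher from compound 2 to compound 3 (the limit leaves the size open). Compound 3 is therefore expected to remain at the limit, with an estimate of 50000 nM in a range from 20000 nM to 100000 nM.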

Compound 3, half-maximal effective concentration: > 50000 nM
Compound 3: only a limit was reported; the forecaster's own chance of this, stated with the estimate: 85%; the middle value sits exactly at the limit.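

No new step can be read among compound 1, compound 2 and compound 3, because in this assay all three give only a limit: the limit of > 50000 nM in this assay, at which 3 of the 3 values shown sit. The compounds shown leave open how far methyl, 1-methyl-1H-pyrazol-5-yl and 2-methylpyridin-4-yl differ from one another on this read-out.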